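Return to a branched benzyl amide on the carbonyl

The source may hold more compounds than are shown below. What is called first, only, known or untested is meant among the compounds shown, and "the series" means these compounds.

Measured so far in an assay on HEK293 cells for displacement of a labelled ligand from Melanocortin receptor 4 (Homo sapiens); on this read-out higher numbers stand for weaker inhibition and lower numbers for stronger inhibition:
compound 1 `CC(C)C[C@H](N)c1cc(C(F)(F)F)ccc1N1CCN(C(=O)C(C)Cc2ccc(Cl)cc2O)CC1` gives 36 nM
compound 2 `CC(C)C[C@H](N)c1cc(F)ccc1N1CCN(C(=O)C(C)Cc2ccc(Cl)cc2)CC1` gives 390 nM
compound 3 `CC(C)C[C@H](N)c1cc(C(F)(F)F)ccc1N1CCN(C(=O)COc2cccc(Cl)c2Cl)CC1` gives 2500 nM

Compound 3 stands at the highest number of the three, with compound 2 nearest and compound 1 furthest. Compound 4 `CCOc1cccc(CC(C)C(=O)N2CCN(c3ccc(C(F)(F)F)cc3[C@@H](N)CC(C)C)CC2)c1` is not yet measured. Its change from compound 3: 1-(3-ethoxybenzyl)ethyl in place of (2,3-dichlorophenoxy)methyl on a carbonyl carbon. Among the measured compounds shown here, the one measured step that bears on it is a 69-fold higher number from compound 1 to compound 3 (1.84 log units; beyond the scatter), which ran in the opposite sense: it put a (2,3-dichlorophenoxy)methyl group onto the carbonyl carbon and the number rose sharply. Compound 4 undoes that and restores a branched benzyl-type group, so a large fall is expected, though likely not the full recovery seen for compound 1. The estimated step is a 17-fold lower number from compound 3 to compound 4 (1.22 log units; beyond the scatter). Compound 4 is expected near 150 nM, within 40 nM to 600 nM.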

Compound 4, inhibition constant: 2200 nM
For compound 4 the middle estimate is 15-fold (1.17 log units) below the measured one; the whole stated range lies below it.
By their numbers in this assay, from the lowest: compound 1; then compound 2; then compounds 4 and 3 (each within the scatter of the next).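

In this assay the branched chain on the carbonyl carbon is not enough by itself: replacing (2,3-dichlorophenoxy)methyl with 1-(3-ethoxybenzyl)ethyl gives a 1.1-fold lower number from compound 3 to compound 4 (0.06 log units; within the scatter). With that chain held constant, 3-ethoxyphenyl in place of 4-chloro-2-hydroxyphenyl gives a 61-fold higher number from compound 1 to compound 4 (1.79 log units; beyond the scatter), so the groups on the phenyl ring of this side chain account for a large difference between these two compounds. Nothing available explains either step.

Still open, as far as these compounds go, is which part of that exchange carries the large step: loss of the chlorine, loss of the hydroxyl or arrival of the ethoxy. A methoxy group on that phenyl ring might help separate these contributions.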